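Acetamido added to a compound sitting at the limit

The compounds below may be only part of what the source reports. "The series", "measured", "known", "first", "only" and "open" are said of these compounds alone.

In a functional assay on HepG2 cells (Homo sapiens) for cytotoxicity, read by MTT assay, with a stated time of 72 h (a lower number here means a stronger inhibitor, a higher number a weaker inhibitor), compound 3 `c1ccc(Nc2ncc3nc(Nc4ccccc4)n(C4CCCC4)c3n2)cc1` gives > 5000 nM, which is a limit and not a number. Compound 1 `CC1CCN(c2ccc(Nc3ncc4nc(Nc5ccccc5)n(C5CCCC5)c4n3)cc2)CC1` gives > 5000 nM, also a limit. Compound 2 `OCCNc1ccc(Nc2ncc3nc(Nc4ccccc4)n(C4CCCC4)c3n2)cc1` gives > 5000 nM, again a limit. The evidence so far is the limit of > 5000 nM in this assay, at which 3 of the 3 values shown sit.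

Compound 4 `CC(=O)Nc1ccc(Nc2ncc3nc(Nc4ccccc4)n(C4CCCC4)c3n2)cc1` differs from compound 3 by acetamido in place of hydrogen on an aromatic carbon, with acetamido in place of hydrogen, para to a large group. The nearest measured changes are a step that the two limits leave unreadable from compound 1 to compound 3 and a step that the two limits leave unreadable from compound 2 to compound 3. They also swap that hydrogen for another group, yet no size can be read from them, so no clear gain in this assay is expected.

The expected change is a step that the limit leaves unreadable from compound 3 to compound 4. For compound 4 the estimate is 8000 nM, with an expected range of 2500 nM to 30000 nM.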

Compound 4, half-maximal inhibitory concentration: > 5000 nM
Compound 4 ended at the assay's limit; the forecaster's own chance of this, stated with the estimate: 85%; the middle value is on the limit's open side.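

In this assay compound 4 gives > 5000 nM, which is a limit and not a number. For the compounds shown here, no step among compound 1, compound 2, compound 3 and compound 4 can be read: the limit of > 5000 nM in this assay, at which 4 of the 4 values shown sit. How strongly any of these compounds acts, and whether changing the group in this place alters that, stays open.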